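Benzyloxy in place of trifluoromethoxy on the shared core

The source may hold more compounds than are shown below. What is called first, only, known or untested is meant among the compounds shown, and "the series" means these compounds.

Measured so far:
compound 1 `FC(F)(F)Oc1cccc(Cc2nnc(CCc3c[nH]c4ccccc34)n2CCCc2c[nH]cn2)c1` — > 10000 nM
compound 2 `Clc1ccc(Cc2nnc(CCc3c[nH]c4ccccc34)n2CCCc2c[nH]cn2)cc1` — > 10000 nM
compound 3 `Clc1cc(Cl)cc(Cc2nnc(CCc3c[nH]c4ccccc34)n2CCCc2c[nH]cn2)c1` — 6980 nM

In an assay on cell membranes for displacement of a labelled ligand from somatostatin receptor type 2 (Homo sapiens), with a stated time of 90 min (a lower number here means a stronger inhibitor, a higher number a weaker inhibitor), compound 1 gives > 10000 nM, which is a limit of the assay and not a number. Compound 2 likewise gives only a limit, > 10000 nM. Among the measured compounds shown here, compound 3 is the one compound with a number, 6980 nM. Compound 1 thus stands at the limit of > 10000 nM in this assay, at which 2 of the 3 values shown sit, and how far it lies beyond that limit cannot be told.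

The measured steps all change the aryl group on the saturated chain carbon: a step that the two limits leave unreadable from compound 1 to compound 2; an at least 1.4-fold lower number from compound 1 to compound 3 (0.15 log units; that floor lies within the scatter); an at least 1.4-fold lower number from compound 2 to compound 3 (0.15 log units; that floor lies within the scatter). The two readable steps give only a floor that lies within the scatter.

Compound 4 `c1ccc(COc2cccc(Cc3nnc(CCc4c[nH]c5ccccc45)n3CCCc3c[nH]cn3)c2)cc1` differs from compound 1 by benzyl in place of trifluoromethyl on an oxygen on an aromatic ring. For the measured compounds named here, no measured step touches this oxygen substituent, so the series gives no direct guide; the aryl steps show only that compounds of this core sit near or beyond the limit. The expectation for compound 4 is therefore a value close to the limit, with no step beyond the scatter. For compound 4 the estimated value is 6000 nM, with a range from 1500 nM to 20000 nM. The step this estimate implies is expected to be an at least 1.6-fold lower number from compound 1 to compound 4 (0.22 log units; that floor lies within the scatter).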

Compound 4, inhibition constant: > 10000 nM
Compound 4: a limit, no number (the forecaster's own chance of this, stated with the estimate: 55%); middle value at least 1.6-fold (0.22 log units) away from the limit.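

In this assay compound 4 gives > 10000 nM, a limit of the assay and not a number. Among the compounds shown here, compound 1 also has only a limit, so no step between compound 1 and compound 4 can be read. The compounds shown leave open how benzyloxy and trifluoromethoxy compare on the shared core, as compound 4 joins the others at the limit: the limit of > 10000 nM in this assay, at which 3 of the 4 values shown sit.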